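The source may hold more compounds than are shown below. What is called first, only, known or untested is meant among the compounds shown, and "the series" means these compounds.

Measured so far:
- compound 1, `CC/C=C\C/C=C\C/C=C\CCCCCCCc1cc(=O)c2c(O)cc(O)cc2o1`: 17500 nM
- compound 2, `CC/C=C\C/C=C\C/C=C\CCCCCCCc1cc(=O)c2c(O)c(C)c(O)cc2o1`: 17500 nM
- compound 3, `CCCCCCCCCCCCCCCc1cc(=O)c2c(O)c(C)c(O)c(C)c2o1`: > 67200 nM

In a functional assay on MCF7 cells (Homo sapiens) for antiproliferative activity, read by MTT assay (a lower number here means a stronger inhibitor, a higher number a weaker inhibitor), compound 1 gives 17500 nM. In this assay compound 2 gives 17500 nM. For compound 3 this assay reports only a limit, > 67200 nM; this is a limit of the measurement and not a number. Among the three values shown, one sits at the limit of > 67200 nM in this assay, at which 1 of the 3 values shown sits.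

Compound 2 and compound 1 share a core and differ in one place, (hydrogen in place of methyl on an aromatic carbon). The step of no change at the digits printed from compound 2 to compound 1 (within the scatter) lies within the scatter, so the two values are treated as the same.

Compound 4, `CCCCCCCCCCCCCCCc1cc(=O)c2c(O)cc(O)c(C)c2o1`, has not been measured in this assay. It differs from compound 3 by hydrogen in place of methyl on an aromatic carbon. This is the same kind of change as that between compound 2 and compound 1, though the surroundings are not identical: in compound 3 the position is also meta to a methyl group, which is not the case for the position in compound 2. How the core of compound 3 differs from the core of compound 2 is not broken down here.

The expectation for compound 4 rests on the step of no change at the digits printed from compound 2 to compound 1 (within the scatter), which showed no effect of removing this methyl, and on the fact that compound 3 is known only as the limit of > 67200 nM in this assay, at which 1 of the 3 values shown sits. Compound 4 is therefore expected to remain weak, with a step that the limit leaves unreadable from compound 3 to compound 4 that is estimated to be small. The estimate for compound 4 is 70000 nM, with an expected range from 25000 nM to 200000 nM, and a fair chance that this assay again reports only a limit.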

Compound 4, half-maximal inhibitory concentration: 17500 nM
The estimate for compound 4 lay 4.0-fold (0.60 log units) above the measured number, outside the stated range (below it).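

In this assay, hydrogen in place of methyl on an aromatic carbon gives an at least 3.8-fold lower number from compound 3 to compound 4 (0.58 log units; beyond the scatter), and this result does not match the same change on the other core: the same change on two cores in this assay, no change at the digits printed (within the scatter) from compound 2 to compound 1 and an at least 3.8-fold lower number (0.58 log units; beyond the scatter) from compound 3 to compound 4, at least 3.8-fold (0.58 log units) apart, beyond the scatter of two such steps. The full size of the step on the core of compound 3 remains unread, as compound 3 is known only as a limit: the limit of > 67200 nM in this assay, at which 1 of the 4 values shown sits. The change therefore cannot be carried from one core to the other as a fixed increment, but the two steps do not show whether the gap between them goes with the chain, with the methyl group meta to the changed position on the core of compound 3, or with both, and two cores give no general rule for the series.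

Still open, as far as these compounds go, is how the same change behaves when only one of these differences between the cores is present, with the chain held the same and the methyl group meta to the changed position either present or absent. Also open, from the compounds shown here alone, is whether an ethyl or methoxy group on the same aromatic carbon would follow the step seen with hydrogen in this assay, and whether a shorter chain would alter the gap between the two steps.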